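Replacing the benzoxazolyl group of compound 3

A few compounds are considered here, and "the series" means these few. Any claim that something is new, unique, unknown or untested is made for them only; others in the source may bear on it.

Three compounds carrying the 1,3-benzoxazol-2-yl group have been measured so far in a functional assay on A2780 cells (Homo sapiens) for cytotoxicity, read by MTT assay, with a stated time of 48 h (on this read-out higher numbers stand for weaker inhibition and lower numbers for stronger inhibition), across the series. Compound 1 (`CCn1cc(-c2nc3ccccc3o2)c(=O)c2cc(F)c(Cl)cc21`) gives 78400 nM there, and compound 2 (`CCn1cc(-c2nc3ccccc3o2)c(=O)c2cc(F)c(N3CCNC(C)C3)c(F)c21`) gives 83500 nM as its value. These two numbers lie within the scatter of each other. Compound 3 (`CCn1cc(-c2nc3ccccc3o2)c(=O)c2cc(F)c(N3CCNCC3)nc21`) gives 15300 nM and stands lowest of the three, beyond the scatter from both of the others.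

Compound 4 (`CCn1cc(-c2nc3ccc(Cl)cc3[nH]2)c(=O)c2cc(F)c(N3CCNCC3)nc21`) keeps the rest of compound 3 and exchanges one group, with 6-chloro-1H-benzimidazol-2-yl in place of 1,3-benzoxazol-2-yl on an aromatic carbon. The change is 6-chloro-1H-benzimidazol-2-yl in place of 1,3-benzoxazol-2-yl on an aromatic carbon and it lies on a six-membered aromatic ring with 1 nitrogen. Within the data shown here, no measured pair isolates this exchange, since all three measured compounds carry the same 1,3-benzoxazol-2-yl group, so the data give no direct guide to its size. A modest move in this assay towards stronger inhibition is expected, and it may not clear the scatter. The estimated change is a 1.5-fold lower number from compound 3 to compound 4 (0.18 log units; within the scatter) and no larger shift is assumed. For compound 4 the expected value is 10000 nM with an estimated range from 3500 nM to 30000 nM on present evidence.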

Compound 4, half-maximal inhibitory concentration: 6300 nM
The estimate for compound 4 lay 1.6-fold (0.20 log units) above the measured number; measured number inside the range.
By their numbers in this assay, from the lowest: compound 4; then compound 3; then compounds 1 and 2 (each within the scatter of the next).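

In this assay the aromatic carbon of the six-membered aromatic ring with 1 nitrogen proves open to change, with a 2.4-fold lower number from compound 3 to compound 4 (0.39 log units; beyond the scatter); the step is modest but beyond the scatter. Among these compounds, this is the first reading at this place, as compound 1, compound 2 and compound 3 all carry 1,3-benzoxazol-2-yl and could say nothing about it. The 6-chloro-1H-benzimidazol-2-yl group keeps the same two ring types as the group it replaces, yet it has 10 heavy atoms rather than 9, 1 hydrogen-bond donor rather than 0 and 1 hydrogen-bond acceptor rather than 2, so a bicyclic group at this place can be altered in these counts and the number still falls.

No supporting data are available to account for this step.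

The exchange alters the five-membered ring and adds the chlorine in a single step, so the share of each remains unresolved; plain 1H-benzimidazol-2-yl, without the chlorine, would divide the two. Going by these compounds, whether a fused bicyclic group is needed here at all also stays open, and a carboxylic acid on the same carbon would test that.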